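Three Close Analogues and an Untested Larger Aryl Group

The compounds below may be only part of what the source reports. "The series", "measured", "known", "first", "only" and "open" are said of these compounds alone.

All measured compounds were tested in an assay on cells for agonist activity at probable G-protein coupled receptor 34 (Mus musculus), with a stated time of 1 h; a higher number here means a larger maximal response, a lower number a smaller maximal response.

Compound 1, `N[C@@H](COP(=O)(O)OCCCOC(=O)CCc1ccccc1OCc1cccc(Oc2ccccc2)c1)C(=O)O`: 19.4%
Compound 2, `N[C@@H](COP(=O)(O)OCCCOC(=O)CCc1ccccc1OCc1cccc(Oc2ccc(Cl)cc2)c1)C(=O)O`: 17.8%
Compound 3, `CCc1ccc(Oc2cccc(COc3ccccc3CCC(=O)OCCCOP(=O)(O)OC[C@H](N)C(=O)O)c2)cc1`: 19.3%

The three compounds share one core and differ only at a single aromatic carbon, which carries hydrogen in compound 1, chloro in compound 2 and ethyl in compound 3. Compound 3 sits among numbers that are all within the scatter of one another: a number 0.1 percentage points lower from compound 1 to compound 3 (within the scatter) and a number 1.5 percentage points higher from compound 2 to compound 3 (within the scatter). Nothing in these three values separates the substituents at that position.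

Compound 4, `Cc1ccccc1-c1ccc(Oc2cccc(COc3ccccc3CCC(=O)OCCCOP(=O)(O)OC[C@H](N)C(=O)O)c2)cc1`, is not yet measured. It differs from compound 3 as follows: 2-methylphenyl in place of ethyl on an aromatic carbon. The two measured steps that touch this carbon, a number 0.1 percentage points lower from compound 1 to compound 3 (within the scatter) and a number 1.5 percentage points higher from compound 2 to compound 3 (within the scatter), were both small. Going by the values given here, the group entering in compound 4 is larger than any tried so far, so there is no measured step that directly covers it, but the only guide available is that changes at this carbon have so far stayed within the scatter. The step is therefore expected to be a number 0.3 percentage points lower from compound 3 to compound 4 (within the scatter). For compound 4 the estimate in this assay is 19%, in a range from 9% to 29%.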

Compound 4, largest response reached (Emax), in percent of the reference or control that the assay uses: 13.4%
Compound 4: the middle estimate sits 5.6 percentage points above what was measured; measured number inside the range.
By their numbers in this assay, from the lowest: compounds 4, 2, 3 and 1 (each within the scatter of the next).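

Replacing ethyl with 2-methylphenyl adds a whole six-membered aromatic ring at this carbon, taking the entering group from 2 heavy atoms to 7, a far bigger structural change than chloro or ethyl. In this assay, the result is a number 5.9 percentage points lower from compound 3 to compound 4 (within the scatter), alongside a number 4.4 percentage points lower from compound 2 to compound 4 (within the scatter) and a number 6 percentage points lower from compound 1 to compound 4 (within the scatter), so these steps are larger than the earlier ones at this carbon, yet all of them remain within the scatter and the four substituents still cannot be told apart. Nothing available gives a reason for these numbers.

The compounds shown leave open whether a plain phenyl, an amine or a carboxylic acid on this carbon would give a step beyond the scatter, and so whether any group here can separate itself from hydrogen. Changes away from this carbon, such as a longer chain in the shared core, also lie outside what these four compounds can speak to.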